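A few compounds are considered here, and "the series" means these few. Any claim that something is new, unique, unknown or untested is made for them only; others in the source may bear on it.

Series notes, values in a functional assay on MDA-MB-435 cells (Homo sapiens) for inhibition, read by sulforhodamine B assay, with a stated time of 48 h; on this read-out higher numbers stand for weaker inhibition of growth and lower numbers for stronger inhibition of growth:

- compound 1 `COc1cc(-c2cc(/C=C/C(=O)c3ccc(N)cc3)[nH]n2)cc(OC)c1OC`: 1660 nM
- compound 2 `COc1cc(-c2cc(/C=C/C(=O)c3ccc(Cl)c(Cl)c3)[nH]n2)cc(OC)c1OC`: 5650 nM
- compound 3 `COc1ccc(C(=O)/C=C/c2cc(-c3cc(OC)c(OC)c(OC)c3)n[nH]2)cc1OC`: 1340 nM

Compound 3 gives the lowest number of the three, but its gap to compound 1 is within the scatter, so the two cannot be ranked against each other; only compound 2 stands apart, as a 4.2-fold lower number from compound 2 to compound 3 (0.62 log units; beyond the scatter) shows. The measured steps compare aryl groups on the carbonyl carbon as whole units: a 3.4-fold higher number from compound 1 to compound 2 (0.53 log units; beyond the scatter) and a 1.2-fold lower number from compound 1 to compound 3 (0.09 log units; within the scatter) are the other two.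

Compound 4 `COc1ccc(C(=O)/C=C/c2cc(-c3cc(OC)c(OC)c(OC)c3)n[nH]2)cc1` differs from compound 3 by hydrogen in place of methoxy on an aromatic carbon. Among the measured compounds shown here, none of the measured steps touches a single methoxy group on that aryl ring; the nearest comparisons are the whole-aryl swaps, where the 3,4-dimethoxyphenyl and 4-aminophenyl sat within the scatter of each other and only the 3,4-dichlorophenyl moved the number by a modest amount. For the measured compounds named here, with no direct precedent, the expected step from compound 3 to compound 4 in this assay is small and likely within the scatter, with a slight lean toward a higher number, expressed as a 1.3-fold higher number from compound 3 to compound 4 (0.13 log units; within the scatter). Compound 4 is accordingly estimated at 1800 nM, with a range of 700 nM to 4500 nM.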

Compound 4, concentration for 50% growth inhibition: 2200 nM
The estimate for compound 4 lay 1.2-fold (0.09 log units) below the measured number; the range from low to high includes it.
By their numbers in this assay, from the lowest: compounds 3, 1 and 4 (each within the scatter of the next); then compound 2.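

In this assay, among the compounds shown here, compound 4 gives the first single-group reading on this aryl ring: going from 3,4-dimethoxyphenyl to 4-methoxyphenyl, with hydrogen in place of methoxy on a carbon ortho to a methoxy group, stays small (a 1.6-fold higher number from compound 3 to compound 4 (0.22 log units; within the scatter)), so that methoxy group has no readable effect on the number. The para-free comparison on the same ring points the same way, since methoxy in place of amino also leaves the number unresolved (a 1.3-fold higher number from compound 1 to compound 4 (0.12 log units; within the scatter)), and compounds 1, 3 and 4 therefore cannot be ranked against one another, while 4-methoxyphenyl in place of 3,4-dichlorophenyl still separates (a 2.6-fold lower number from compound 2 to compound 4 (0.41 log units; beyond the scatter)), leaving compound 2 as the only one apart. Nothing at hand bears on what lies behind these steps.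

Open, going by these compounds, is whether the higher number of compound 2 follows from one chlorine or from both, which a single chlorine on this ring would settle. Also open, on these data alone, is how far this aryl ring tolerates other groups, such as a hydroxy group, a carboxylic acid or a longer alkoxy chain in place of the remaining methoxy, and whether the other aryl ring, the same in all four compounds, is as forgiving.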